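A methoxy group added to compound 1

The source may report more compounds than this note shows. Statements on the series, on what has been measured and on what is new or still open speak of the compounds shown alone.

In a functional assay on PC-12 cells (Rattus norvegicus) for cytotoxicity, read by MTT assay, with stated times of 36 h and 12 h (a higher number here means that more compound is needed for the effect, a lower number that less compound is needed), compound 1 `Cc1nc(C)c(COCc2ccc(OCc3nc(C)c(C)nc3C)cc2)nc1C` gives 1660 nM and compound 2 `Cc1nc(C)c(COCCc2ccc(OCc3nc(C)c(C)nc3C)cc2)nc1C` gives 2030 nM. Among the compounds with values here, these are the only two numbers available, and they lie within the scatter of each other, so compound 1 does not stand apart from its single neighbour.

Compound 3 `COc1cc(COCc2nc(C)c(C)nc2C)ccc1OCc1nc(C)c(C)nc1C` has not yet been measured. It differs from compound 1 by one change methoxy in place of hydrogen on an aromatic carbon of a six-membered aromatic ring of carbon only, ortho to a large group and meta to a large group.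

No measured pair shows what this change does, and the data give no reason to favour either direction. Within the data shown here, the only guide is how close together the two measured values sit, with compound 1 at 1660 nM and compound 2 at 2030 nM. In this assay the expected step of a 1.1-fold higher number from compound 1 to compound 3 (0.04 log units; within the scatter) therefore stays within the scatter, although the uncertainty is wide. For compound 3 the estimated value is 1800 nM, with an expected range (600 nM to 5500 nM).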

Compound 3, half-maximal effective concentration: 1070 nM
Estimate against measurement, compound 3: 1.7-fold (0.23 log units) above; low and high end bracket the measured number.
By their numbers in this assay, from the lowest: compounds 3, 1 and 2 (each within the scatter of the next).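

In this assay, methoxy in place of hydrogen on an aromatic carbon of the six-membered ring, ortho to a large group and meta to a large group, comes with a 1.6-fold lower number from compound 1 to compound 3 (0.19 log units; within the scatter) and so gives no sign of a real difference in either direction. Within the data shown here, this is the first single-place step available, and it shows that this ring carbon of the core of compound 1 can carry a methoxy group while the read-out stays in the same range as that of compound 1. No accompanying measurement bears on why the number falls where it does.

On these data alone, whether this position accepts other groups just as readily, such as hydroxy, ethoxy, an amine or a carboxylic acid, remains open, since a single methoxy step cannot show how far that acceptance extends. Also open, as far as these compounds go, is whether methoxy behaves the same way on the other carbons of this ring, on the second aromatic ring of the molecule or on the core of compound 2.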